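The source may hold more compounds than are shown below. What is called first, only, known or untested is meant among the compounds shown, and "the series" means these compounds.

Two compounds of this series have numbers in a functional assay on CHO cells for antagonist activity at Orexin/Hypocretin receptor type 1 (Homo sapiens), read by FLIPR and calcium flux; a lower number here means a less potent compound, a higher number a more potent compound, by a factor of ten per unit of this negative logarithm. Compound 1, `Cc1cnn(-c2ccc(C)nc2C(=O)N2CC3(CC3)C[C@H]2CNc2ccc(C(F)(F)F)cn2)c1`, gives 8.9 in this assay, the higher of the two values. Compound 2, `Cc1ccc(-n2nccn2)c(C(=O)N2CCC3(CC3)C[C@H]2CNc2cccc(C)n2)c1`, gives 8.2 in this assay, a gap to compound 1 that lies beyond the usual scatter, though the two differ in more than one place and no single step can be read from them.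

Compound 3, `Cc1ccc(OCc2ccccc2)c(C(=O)N2CC3(CC3)C[C@H]2CNc2ccc(C(F)(F)F)cn2)n1`, is not yet measured. It differs from compound 1 in one place: benzyloxy in place of 4-methyl-1H-pyrazol-1-yl on an aromatic carbon, a benzyloxy in place of 4-methyl-1H-pyrazol-1-yl on an aromatic carbon. Within the data shown here, no measured pair in the set tracks this exchange, so the expectation rests on compound 1 alone.

The expected step of a number 0.50 log units lower from compound 1 to compound 3 (beyond the scatter) is a modest loss, of a size somewhat beyond the scatter. Compound 3 is thus estimated at 8.4 in this assay. The expected range for compound 3 is estimated to run from 7.7 to 9.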

Compound 3, negative logarithm of the antagonist equilibrium constant: 8.6
Estimate against measurement, compound 3: 0.20 log units below, within the range that was stated.
By their numbers in this assay, from the lowest: compound 2; then compounds 3 and 1 (each within the scatter of the next).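

On the six-membered aromatic ring with 1 nitrogen, at the carbon ortho to a large group, benzyloxy in place of 4-methyl-1H-pyrazol-1-yl gives a number 0.30 log units lower from compound 1 to compound 3 (within the scatter) in this assay as the read-out. Among these compounds, this is the first single-place comparison: at this position, a six-membered aromatic ring of carbon only, carried by benzyloxy, stands in for a five-membered aromatic ring with 2 hetero atoms with no step beyond the scatter. Nothing on hand gives a reason for this result.

Open, as far as these compounds go, is whether this position also tolerates a group without an aromatic ring, such as an amine, a carboxylic acid or a longer chain. Also open, from the compounds shown here alone, is whether the same exchange gives a step of like size on a core other than that of compound 1.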